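Exchanging 4-methylphenyl for 3-methoxyphenyl on a carbonyl carbon

The compounds below may be only part of what the source reports. "The series", "measured", "known", "first", "only" and "open" are said of these compounds alone.

The measured compounds, each with its value in a functional assay on CHO cells for agonist activity at muscarinic acetylcholine receptor M5 (Rattus norvegicus); a higher number here means that more compound is needed for the effect, a lower number that less compound is needed:

Compound 1, `CCOC(=O)N1CCC(N2CCC[C@@H](NC(=O)C3CCCC3)C2)CC1`. In this assay compound 1 gives > 10000 nM, which is a limit of the assay and not a number.
Compound 2, `CCOC(=O)N1CCC(NCCNC(=O)c2ccccc2C)CC1`. In this assay compound 2 gives > 30000 nM, again a limit rather than a number.
Compound 3, `CCOC(=O)N1CCC(N2CCC[C@@H](NC(=O)c3ccc(C)cc3)C2)CC1`. In this assay compound 3 gives > 10000 nM, also a limit.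

Compound 3 therefore stands at a limit, and the two further values are limits as well: the limit of > 10000 nM in this assay, at which 2 of the 3 values shown sit, and (the limit of > 30000 nM in this assay, at which 1 of the 3 values shown sits). Among the measured compounds shown here, the one step between measured compounds, a step that the two limits leave unreadable from compound 1 to compound 3, cannot be read in size because both ends are limits.

Compound 4 is `CCOC(=O)N1CCC(N2CCC[C@@H](NC(=O)c3cccc(OC)c3)C2)CC1`. Its difference from compound 3 is 3-methoxyphenyl in place of 4-methylphenyl on a carbonyl carbon.

For the measured compounds named here, no measured step bears readably on this change, so no direction can be taken from the data, and no step beyond the scatter is expected. Compound 4 is expected to give about 15000 nM in this assay, with a range from 3000 nM to 60000 nM. This estimate means a step that the limit leaves unreadable from compound 3 to compound 4, most likely again reported only as a limit.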

Compound 4, half-maximal effective concentration: > 10000 nM
Compound 4: only a limit was reported (the forecaster's own chance of this, stated with the estimate: 80%); the middle value does not contradict the limit.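

Compound 4 gives only a limit, so the steps from compound 1 and compound 3 to compound 4 cannot be read in size: the limit of > 10000 nM in this assay, at which 3 of the 4 values shown sit.

The compounds shown leave open whether any group on the carbonyl carbon gives a measurable value in this assay.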